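Swapping the tert-butyl amide for a 4-chlorophenyl amide

The source may hold more compounds than are shown below. What is called first, only, known or untested is meant among the compounds shown, and "the series" means these compounds.

Measured compounds:
compound 1 `CC(C)(C)C(=O)N1CCCn2nc(COc3ccccc3)cc21`, 64%
compound 2 `O=C(C1CCC1)N1CCCn2nc(COc3ccccc3)cc21`, 41%
compound 3 `O=C(c1ccc(F)cc1)N1CCCn2nc(COc3ccccc3)cc21`, 63%

In a functional assay on HEK293 cells for positive allosteric modulation of metabotropic glutamate receptor 5 (Homo sapiens), read by calcium flux (a lower number here means a smaller maximal response, a higher number a larger maximal response), compound 1 gives the highest of the three numbers. Compound 3 lies close to it, and that gap is within the scatter, so no order between the two can be claimed. Compound 2 sits clearly lower: a number 23 percentage points lower from compound 1 to compound 2 (beyond the scatter) and a number 22 percentage points higher from compound 2 to compound 3 (beyond the scatter) show that the cyclobutyl amide falls short of both the tert-butyl and the 4-fluorophenyl amides.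

Compound 4 `O=C(c1ccc(Cl)cc1)N1CCCn2nc(COc3ccccc3)cc21` has not yet been measured. Compared with compound 1 it differs in one place: 4-chlorophenyl in place of tert-butyl on a carbonyl carbon.

The step that bears most directly on this change is a number 1 percentage points lower from compound 1 to compound 3 (within the scatter), where a different 4-halophenyl group replaced the same tert-butyl group without a change beyond the scatter. A 4-chlorophenyl group is a close relative of that 4-fluorophenyl group, so no step beyond the scatter is expected in this assay . The estimate for compound 4 is therefore 60%, with a range from 45% to 75%, which is expected to mean a step of a number 4 percentage points lower from compound 1 to compound 4 (within the scatter).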

Compound 4, largest response reached (reported as percent of maximum), in percent of the reference or control that the assay uses: 68%
The estimate for compound 4 lay 8 percentage points below the measured number, within the range that was stated.
By their numbers in this assay, from the lowest: compound 2; then compounds 3, 1 and 4 (each within the scatter of the next).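

In this assay, a second 4-halophenyl amide now stands level with the tert-butyl amide, with a number 4 percentage points higher from compound 1 to compound 4 (within the scatter), so at this carbonyl carbon the 4-chlorophenyl group can replace tert-butyl without a readable change. Exchanging the halogen alone also leaves the reading in place, with a number 5 percentage points higher from compound 3 to compound 4 (within the scatter), whereas the cyclobutyl amide remains clearly apart from this new compound, with a number 27 percentage points higher from compound 2 to compound 4 (beyond the scatter). No measurement available here explains why the cyclobutyl amide differs from the other three.

The compounds shown leave open whether a pyridyl ring or a longer chain such as n-butyl at the same carbonyl carbon would hold this level of response. They also leave open whether chloro in place of fluoro would read the same on a different core.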